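The source may hold more compounds than are shown below. What is called first, only, known or untested is meant among the compounds shown, and "the series" means these compounds.

Working notes on the series.

Compound 3 `CCS(=O)(=O)N[C@@H]1CCCc2c1cncc2N1Cc2cc(Cl)ccc2C1=O` sits second highest of the three numbers in an assay on cells for inhibition of cytochrome P450 11B2, mitochondrial (Homo sapiens), read by HTRF (a higher number here means a weaker inhibitor, a lower number a stronger inhibitor), where compound 3 gives 40 nM. The nearest value belongs to compound 2 `CCC(=O)N[C@@H]1CCCc2c1cncc2N1C(=O)c2ccc(Cl)cc2[C@@H]1CC`, which in this assay gives 12 nM, a lower number beyond the scatter. The furthest is compound 1 `CC(=O)N[C@H]1CCCc2c1cncc2N1Cc2cc(Cl)ccc2C1=O`, which in this assay gives 5140 nM, far higher than either. For the measured compounds named here, compounds 1 and 2 differ from compound 3 in more than one place, so no single step between them can be read off.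

Compound 4 `CCC(=O)N[C@@H]1CCCc2c1cncc2N1Cc2cc(Cl)ccc2C1=O` is the next compound, not yet measured. It differs from compound 3 in one place: propanoyl in place of ethylsulfonyl on an amine nitrogen. Going by the values given here, no measured pair in this set isolates that change, so the direction of the step is open; the expectation is a small movement, not clearly beyond the scatter, from compound 3 to compound 4 of a 1.3-fold lower number from compound 3 to compound 4 (0.12 log units; within the scatter). Compound 4 is accordingly expected to give about 30 nM in this assay, with a plausible range from 8 nM to 120 nM.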

Compound 4, half-maximal inhibitory concentration: 28 nM
Beside the measured number, compound 4's estimate is 1.1-fold (0.03 log units) above it, and the stated range covers the measured number.
By their numbers in this assay, from the lowest: compound 2; then compounds 4 and 3 (each within the scatter of the next); then compound 1.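

In this assay, the step of a 1.4-fold lower number from compound 3 to compound 4 (0.15 log units; within the scatter) lies within the scatter, so on this amine nitrogen, whose other neighbour is a saturated ring carbon, the data do not separate propanoyl from ethylsulfonyl. The ring substituent now has a readable step of its own: hydrogen in place of ethyl on a saturated ring carbon gives a 2.3-fold higher number from compound 2 to compound 4 (0.37 log units; beyond the scatter), modest but beyond the scatter. The data shown offer no explanation for either step.

The compounds shown leave open whether a methyl or a longer chain on that saturated ring carbon would give a different number from ethyl. They also leave open whether a urea, a carbamate or a methylsulfonyl group on the amine nitrogen would stay within the scatter of propanoyl and ethylsulfonyl.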